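Mirror Image of Compound 3 Awaits Its Number

The source may report more compounds than this note shows. Statements on the series, on what has been measured and on what is new or still open speak of the compounds shown alone.

Three ureas have been measured in an ADME assay on the whole organism with Oryza sativa as the target, tested at 0.1 uM; a higher number here means a weaker effect of the compound at the concentration tested, a lower number a stronger effect. Compound 1 `CC(C)c1cccc(NC(=O)N[C@@H](C)c2ccccc2)c1` gives 95%, compound 2 `CCOC(=O)c1cccc(NC(=O)N[C@@H](C)c2ccccc2)c1` gives 100% and compound 3 `COc1cccc(NC(=O)N[C@H](C)c2ccccc2)c1` gives 104%. For the measured compounds named here, the only one-place step measured so far, a number 5 percentage points higher from compound 1 to compound 2 (within the scatter), stays within the scatter. Compound 3 stands at the highest of the three numbers, but its gaps to compound 2 and to compound 1 are both within the scatter, so no order among them can be claimed. Compound 4 `COc1cccc(NC(=O)N[C@@H](C)c2ccccc2)c1` differs from compound 3 in this way: the two compounds have the same atoms and bonds and differ only in configuration as drawn: 1 of 1 stereo elements differ; a stereocentre at a saturated chain carbon is drawn R in compound 3 and S in compound 4. Going by the values given here, no measured step concerns a change of configuration alone, and the single step available was within the scatter, so the expected step is a number 4 percentage points lower from compound 3 to compound 4 (within the scatter), none beyond the scatter. The estimate for compound 4 is 100%, between 90% and 110%.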

Compound 4, a percentage reported as activity, at one concentration (the size of the read-out at that concentration, not a potency): 101%
Beside the measured number, compound 4's estimate is 1 percentage points below it; the range from low to high includes it.
By their numbers in this assay, from the lowest: compounds 1, 2, 4 and 3 (each within the scatter of the next).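

For the compounds shown here, the pair gives the first reading in this assay of a change of configuration alone, and a number 3 percentage points lower from compound 3 to compound 4 (within the scatter), so inverting the saturated chain carbon with methoxy on the aromatic carbon shows no difference beyond the scatter. That reading concerns one change only: the fact that compounds 3 and 4 differ only in the configuration as drawn

With the configuration of compounds 1 and 2 kept, the aromatic group also gives no separation, with a number 1 percentage points higher from compound 2 to compound 4 (within the scatter) for methoxy in place of ethoxycarbonyl and a number 6 percentage points higher from compound 1 to compound 4 (within the scatter) for methoxy in place of isopropyl. Going by these compounds, whether a carboxylic acid or an amine on that aromatic carbon would move the number beyond the scatter remains open. So does whether configuration matters with any group other than methoxy there.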